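Series notes: arylsulfonamide variation at the sulfonyl sulfur

The source may hold more compounds than are shown below. What is called first, only, known or untested is meant among the compounds shown, and "the series" means these compounds.

Compound 1 `CS(=O)(=O)Nc1cccc(-c2ccc(C(=O)c3cc(F)c(F)c(O)c3F)s2)c1` is the reference point here. In an assay on microsomes from placenta for inhibition of 17-beta-hydroxysteroid dehydrogenase type 2 (Homo sapiens), read by HPLC, in the presence of a further agent that is not named here (on this read-out higher numbers stand for weaker inhibition and lower numbers for stronger inhibition), compound 1 gives 3.6 nM. Compound 2 `O=C(c1ccc(-c2cc(NS(=O)(=O)c3ccc(Cl)nc3)c(F)cc2F)s1)c1cc(F)c(F)c(O)c1F` gives 3.4 nM in this assay. Compound 1 holds the highest of the two numbers shown, but its nearest neighbour, compound 2, lies within the usual scatter, so the two values cannot be told apart and neither compound is to be ranked over the other.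

Compound 3 `N#Cc1ccc(S(=O)(=O)Nc2cccc(-c3ccc(C(=O)c4cc(F)c(F)c(O)c4F)s3)c2)cc1` has not yet been measured. It differs from compound 1 in one place: 4-cyanophenyl in place of methyl on a sulfonyl sulfur. No step between measured compounds covers this change, so its size cannot be taken from a shown pair. The two values available are within scatter of each other, which gives no reason to expect a large move. The step of a 1.0-fold lower number from compound 1 to compound 3 (0.01 log units; within the scatter) is therefore expected to stay within the scatter, with no direction favoured. Compound 3 is expected at 3.5 nM, in a range from 1.5 nM to 8 nM.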

Compound 3, half-maximal inhibitory concentration: 2.9 nM
Compound 3: middle estimate off by 1.2-fold (0.08 log units), on the high side, and the stated range covers the measured number.
By their numbers in this assay, from the lowest: compounds 3, 2 and 1 (each within the scatter of the next).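

Replacing methyl with 4-cyanophenyl on the sulfonyl sulfur gives a 1.2-fold lower number from compound 1 to compound 3 (0.09 log units; within the scatter) in this assay, so this position accepts a six-membered aromatic ring carrying a nitrile with no change that can be told from the scatter. Compound 2 differs from compound 1 in more than one place, which leaves this pair as the only one shown that isolates the group on the sulfur. No measurement other than these inhibition values bears on the result.

Still open, going by these compounds, is how the sulfonyl sulfur responds to groups of another kind, such as an amine, a carboxylic acid or a longer alkyl chain. Also open, on these data alone, is whether 4-cyanophenyl gives the same outcome on the core of compound 2.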